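The source may hold more compounds than are shown below. What is called first, only, known or untested is meant among the compounds shown, and "the series" means these compounds.

In a functional assay on PC-3 cells (Homo sapiens) for antiproliferative activity, read by CCK-8 assay, with a stated time of 6 days (on this read-out higher numbers stand for weaker inhibition and lower numbers for stronger inhibition), compound 1 (`N#Cc1ccc(N2CCc3cc(-c4cncnc4)ccc32)cc1C(F)(F)F`) carries the entry "not determined" (no result reported) and so offers no number for comparison. Compound 2 (`CCN(c1ccc(C#N)c(Cl)c1)c1cc(-c2cnc3ccccc3c2)ccc1C`) stands at 3570 nM and compound 3 (`CCN(c1ccc(C#N)c(Cl)c1)c1cc(-n2cnc3ccccc32)ccc1C`) at 8160 nM as the higher of the two available numbers, so compound 3 is the weaker inhibitor of this pair, with a gap beyond the usual scatter.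

One change leads from compound 3 to compound 4 (`CCN(c1ccc(C#N)c(Cl)c1)c1cc(-c2ccco2)ccc1C`): furan-2-yl in place of 1H-benzimidazol-1-yl on an aromatic carbon (furan-2-yl in place of 1H-benzimidazol-1-yl on an aromatic carbon, para to a methyl group).

Among the measured compounds shown here, no step between measured compounds that differ in one place is available, so the expectation rests on thin ground. For the measured compounds named here, with compound 2 at 3570 nM against compound 3 at 8160 nM as the only numbers, a step in this assay toward a lower number is expected, of a size near the scatter and possibly not beyond it. The estimated move is a 1.6-fold lower number from compound 3 to compound 4 (0.21 log units; within the scatter) as a working figure for these notes. For compound 4 the estimated value is 5000 nM with an expected range from 2000 nM to 12000 nM across repeated measurements.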

Compound 4, half-maximal inhibitory concentration: > 30000 nM
Compound 4: no number, only a limit (the forecaster's own chance of this, stated with the estimate: 10%); at least 6.0-fold (0.77 log units) between middle value and limit.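

In this assay, compound 4 gives > 30000 nM, which is a limit of the assay and not a number. Furan-2-yl in place of 1H-benzimidazol-1-yl, on the aromatic carbon para to a methyl group, gives an at least 3.6-fold higher number from compound 3 to compound 4 (0.56 log units; beyond the scatter), so the read-out at this position responds to the group placed there, and the swap from 9 heavy atoms to 5 comes with a step beyond the scatter. Only the minimum size of this step can be read, and its full size stays unknown: the limit of > 30000 nM in this assay, at which 1 of the 4 values shown sits.

The single change removes the six-membered aromatic ring of carbon only, replaces two nitrogen hetero atoms with one oxygen, and shortens the group, so the compounds shown cannot separate which of these features goes with the step. Also open, from the compounds shown here alone, is how a plain phenyl ring, or a furan-2-yl carrying an aminomethyl group or a carboxylic acid, would stand at this position in this assay.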